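From Methoxy to Chloro on the Fluorophenyl Amide

The compounds below may be only part of what the source reports. "The series", "measured", "known", "first", "only" and "open" are said of these compounds alone.

Compound 1 `CS(=O)(=O)N1C[C@H](C(=O)Nc2ccc3[nH]ccc3c2)[C@@H](C(=O)Nc2ccc(-n3ccccc3=O)cc2F)C1` and compound 2 `COc1ccc(NC(=O)[C@H]2CN(S(C)(=O)=O)C[C@@H]2C(=O)Nc2ccc(-n3ccccc3=O)cc2F)cc1F` share a core and differ only in the aryl group on one amide nitrogen. In a physicochemical assay for lipophilicity, at pH 7.4 (a lower number here means a more polar compound, a higher number a more lipophilic compound), compound 1 gives 1.07 and compound 2 gives 0.56, the lower of the two numbers. Compound 3 `CS(=O)(=O)N1C[C@H](C(=O)Nc2ccc(Cl)c(F)c2)[C@@H](C(=O)Nc2ccc(-n3ccccc3=O)cc2F)C1` differs from compound 2 in that same aryl group, with chloro in place of methoxy on an aromatic carbon, ortho to a fluoro group (chloro in place of methoxy on an aromatic carbon). Within the data shown here, no measured pair makes this exchange. Among the measured compounds shown here, the only guide is the single measured step at this aryl group, a number 0.51 log units lower from compound 1 to compound 2 (beyond the scatter), which is modest but beyond the scatter. The expected step is upward and of similar modest size, a number 0.64 log units higher from compound 2 to compound 3 (beyond the scatter). Compound 3 is estimated at 1.2, with an expected range from 0.85 to 1.55.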

Compound 3, distribution coefficient: 2.37
Beside the measured number, compound 3's estimate is 1.17 log units below it; the measured number lies above the stated range.
By their numbers in this assay, from the lowest: compound 2; then compound 1; then compound 3.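

In this assay, this aryl group proves able to carry a far bigger change than the earlier pair showed: chloro in place of methoxy gives a number 1.81 log units higher from compound 2 to compound 3 (beyond the scatter), and 4-chloro-3-fluorophenyl in place of 1H-indol-5-yl gives a number 1.30 log units higher from compound 1 to compound 3 (beyond the scatter). Both steps are large, whereas the earlier step at this aryl group, a number 0.51 log units lower from compound 1 to compound 2 (beyond the scatter), was modest, so exchanging one substituent on the ring, with the fluoro group kept, moves the number further than replacing the whole aryl group did between those two compounds. Nothing available accounts for the size of this step.

The compounds shown leave open whether a step of this size belongs to chloro alone or would also appear with a nitrile, a trifluoromethyl group or an amine on the same aromatic carbon. They also leave open whether it would hold with hydrogen in place of the fluoro group.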